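Indolyl for dimethoxyphenyl on the enamine nitrogen

This account rests on a few compounds, and the source may have more. Where it says the series, first, only, none or still open, it means among the compounds named here.

Compound 1 `COc1ccc(N/C=C\C(=O)c2nc(-c3ccc(F)cc3)n3ccccc23)cc1` gives 19200 nM in a functional assay on A549 cells (Homo sapiens) for cytotoxicity, read by MTT assay, with a stated time of 48 h; on this read-out lower numbers stand for stronger inhibition and higher numbers for weaker inhibition. For compound 2 `COc1ccc(N/C=C\C(=O)c2nc(-c3ccc(F)cc3)n3ccccc23)cc1OC` the read-out in this assay is a limit, > 30000 nM, and compound 2 therefore stands at the weak end of the pair with only a floor known (the limit of > 30000 nM in this assay, at which 1 of the 2 values shown sits). Among the compounds with values here, the single measured step is an at least 1.5-fold higher number from compound 1 to compound 2 (0.19 log units; that floor lies within the scatter). Compound 3 `Cc1cc2cc(N/C=C\C(=O)c3nc(-c4ccc(F)cc4)n4ccccc34)ccc2[nH]1` brings (2-methyl-1H-indol-5-yl in place of 3,4-dimethoxyphenyl on an amine nitrogen). Within the data shown here, no measured step exchanges the whole aryl group on that nitrogen, and an at least 1.5-fold higher number from compound 1 to compound 2 (0.19 log units; that floor lies within the scatter) bears on it only loosely. In this assay the expected step is of uncertain direction, an at least 1.5-fold lower number from compound 2 to compound 3 (0.17 log units; that floor lies within the scatter). Compound 3 is estimated at 20000 nM, within 5000 nM to 80000 nM.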

Compound 3, half-maximal inhibitory concentration: > 30000 nM
Compound 3 ended at the assay's limit (the forecaster's own chance of this, stated with the estimate: 40%); middle value at least 1.5-fold (0.17 log units) away from the limit.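

In this assay the exchange of 4-methoxyphenyl for 2-methyl-1H-indol-5-yl on the amine nitrogen gives an at least 1.5-fold higher number from compound 1 to compound 3 (0.19 log units; that floor lies within the scatter). The new point is that a two-ring aryl group with a hydrogen-bond donor at this position, and not only a second methoxy, also ends at the limit of the read-out: the limit of > 30000 nM in this assay, at which 2 of the 3 values shown sit. The step between compound 2 and compound 3 cannot be read: both values are limits.

Going by these compounds, how far either group lies past that limit stays open. Also open, on these data alone, is whether an aryl group carrying an amine or a carboxylic acid on this nitrogen would read lower than compound 1.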